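The compounds below may be only part of what the source reports. "The series", "measured", "known", "first", "only" and "open" are said of these compounds alone.

Measured so far, in a functional assay on PC-3 cells (Homo sapiens) for inhibition, read by sulforhodamine B assay, with a stated time of 48 h; a lower number here means a stronger inhibitor, a higher number a weaker inhibitor:
compound 1, `O=c1c([C@@H]2C[C@H](c3ccccc3)ON2c2ccccc2)coc2ccc(F)cc12`: 49000 nM.
compound 2, `Cc1ccc2occ([C@@H]3C[C@H](c4ccccc4)ON3c3ccccc3)c(=O)c2c1`: compound 2 reaches only the limit of the assay, > 60000 nM.
compound 3, `O=c1c([C@@H]2C[C@H](c3ccccc3)ON2c2ccccc2)coc2ccccc12`: compound 3 likewise gives only the limit, > 60000 nM.

Compound 2 thus stands at the ceiling of what this assay reports, a limit it shares with compound 3: the limit of > 60000 nM in this assay, at which 2 of the 3 values shown sit. Only compound 1 gives a number. The steps among the measured compounds all concern the substituent on the aromatic carbon of the shared core: an at least 1.2-fold higher number from compound 1 to compound 2 (0.08 log units; that floor lies within the scatter); an at least 1.2-fold higher number from compound 1 to compound 3 (0.08 log units; that floor lies within the scatter); and a step that the two limits leave unreadable from compound 2 to compound 3.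

Compound 4, `Cc1ccc2occ([C@@H]3C[C@H](OCC(C)C)ON3c3ccccc3)c(=O)c2c1`, changes compound 2 at a different place: isobutoxy in place of phenyl on a saturated ring carbon. For the measured compounds named here, no measured step touches this saturated ring carbon, so none of the three steps bears on the change, and the expectation rests on compound 2 alone, which sits at the limit. With nothing to argue for a move beyond the scatter, the expected step is a number no higher from compound 2 to compound 4 (the limit leaves the size open). For compound 4 the estimate in this assay is 60000 nM, with a range from 20000 nM to 150000 nM, and a fair chance that only a limit is reported again.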

Compound 4, half-maximal inhibitory concentration: 37700 nM
Beside the measured number, compound 4's estimate is 1.6-fold (0.20 log units) above it, and the stated range covers the measured number.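

Earlier steps touched only the substituent on the aromatic carbon of the shared core, whereas this change shows that the saturated ring carbon next to the ring oxygen can also be varied: with isobutoxy in place of phenyl, this assay returns a number rather than a limit. The step is an at least 1.5-fold lower number from compound 2 to compound 4 (0.20 log units; that floor lies within the scatter), so with the methyl-bearing core, phenyl at this carbon is not needed for a readable value, though this rests on a single pair and a floor that does not exceed the usual scatter. The real size of the step cannot be read, since compound 2 gives no number, only a limit: the limit of > 60000 nM in this assay, at which 2 of the 4 values shown sit.

The change removes an aromatic ring and brings in an oxygen-linked branched chain together, so the compounds shown cannot separate the contribution of the ring from that of the ether oxygen or the branching. Also open, as far as these compounds go, are how a plain methoxy, a longer unbranched alkoxy chain or an amine-bearing chain would read at this carbon, and whether isobutoxy behaves alike with fluoro on the aromatic carbon, as in compound 1.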